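The compounds below may be only part of what the source reports. "The series", "measured", "known", "first", "only" and "open" are said of these compounds alone.

Measured compounds in a functional assay on HeLa cells (Homo sapiens) for inhibition, read by CCK-8 assay, with a stated time of 72 h, tested at 2 uM; a lower number here means less inhibition of growth, a higher number more inhibition of growth at the concentration tested:
compound 1, `COc1ccc(SCc2ccc(/C=C/C(=O)Nc3ccccc3N)cc2)cc1OC`: 10.1%
compound 2, `Nc1ccccc1NC(=O)c1ccc(CSc2ccc(C(F)(F)F)cn2)cc1`: 11.5%
compound 3, `COc1ccc(SCc2ccc(C(=O)Nc3ccccc3N)cc2)cc1`: 35%

Compound 1 gives the lowest of the three numbers in this assay. Compound 2 sits nearest, within the scatter, so no order between compound 1 and compound 2 can be read. Compound 3 stands furthest, beyond the scatter, with the higher number of the two.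

Compound 4, `Nc1ccccc1NC(=O)/C=C/c1ccc(CSc2cccc(F)c2)cc1`, has yet to be measured in this assay. Against compound 1 the change is 3-fluorophenyl in place of 3,4-dimethoxyphenyl on a sulfur. Going by the values given here, no measured pair shows this change, so its effect is unknown. The step from compound 1 to compound 4 in this assay is expected to stay within the scatter, with no clear direction: a number 3.9 percentage points higher from compound 1 to compound 4 (within the scatter). Compound 4 is therefore estimated at 14%, in a range from 3% to 30%.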

Compound 4, percent growth inhibition at one concentration: 2.25%
Compound 4: middle estimate off by 11.8 percentage points, on the high side; measured number below the stated range.
By their numbers in this assay, from the lowest: compounds 4, 1 and 2 (each within the scatter of the next); then compound 3.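

In this assay the exchange on the sulfur gives a number 7.9 percentage points lower from compound 1 to compound 4 (within the scatter) and so leaves the reading unresolved. The 3,4-dimethoxyphenyl group, with 10 heavy atoms and 2 hydrogen-bond acceptors, can therefore give way to 3-fluorophenyl, with 7 heavy atoms and 0 hydrogen-bond acceptors, without a change that can be read at this concentration. No measurement available here offers an explanation for this result.

From the compounds shown here alone, whether an amine or a carboxylic acid on the ring attached to this sulfur would shift the reading remains open. A single pair also cannot show whether this exchange behaves the same way on other cores.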